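Butylamino in Place of Methylamino: A Cytotoxicity Estimate

A few compounds are considered here, and "the series" means these few. Any claim that something is new, unique, unknown or untested is made for them only; others in the source may bear on it.

Compound 1 (`CC(C)(C)C1=CC(=O)C=CC1=O`): 72000 nM
Compound 2 (`CC(C)(C)C1=CC(=O)C(NCc2ccccc2)=CC1=O`): 15000 nM
Compound 3 (`CNC1=CC(=O)C(C(C)(C)C)=CC1=O`): 58000 nM

In a functional assay on NCI-H460 cells (Homo sapiens) for cytotoxicity, read by MTT assay, with a stated time of 72 h (a higher number here means a weaker inhibitor, a lower number a stronger inhibitor), compound 3 lies level with the core of compound 1, as a 1.2-fold lower number from compound 1 to compound 3 (0.09 log units; within the scatter) shows, and clearly apart from the benzylamino compound, as a 3.9-fold higher number from compound 2 to compound 3 (0.59 log units; beyond the scatter) shows. Compound 4 (`CCCCNC1=CC(=O)C(C(C)(C)C)=CC1=O`) follows with propyl in place of hydrogen on a saturated chain carbon bound to an amine nitrogen, which turns methylamino into butylamino. The closest evidence is the modest step of a 3.9-fold higher number from compound 2 to compound 3 (0.59 log units; beyond the scatter), which is a change at the same place, though phenyl is not propyl. Read in reverse, it suggests that a larger group there may lower the number. This is a single step, so it shows no general pattern, and butylamino may fall short of benzylamino. A modest fall is therefore expected, of about a 1.9-fold lower number from compound 3 to compound 4 (0.29 log units; within the scatter). Compound 4 is expected at 30000 nM, with an estimated range of 12000 nM to 70000 nM.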

Compound 4, half-maximal inhibitory concentration: 72000 nM
For compound 4 the middle estimate is 2.4-fold (0.38 log units) below the measured one; measured number outside the range, above it.
By their numbers in this assay, from the lowest: compound 2; then compounds 3, 1 and 4 (each within the scatter of the next).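

In this assay, the longer chain at this place on a saturated chain carbon bound to an amine nitrogen makes no difference that can be read: butylamino and methylamino match, with a 1.2-fold higher number from compound 3 to compound 4 (0.09 log units; within the scatter). Butylamino also leaves the number level with the unsubstituted core, with no change at the digits printed from compound 1 to compound 4 (within the scatter), whereas propyl in place of phenyl gives a 4.8-fold higher number from compound 2 to compound 4 (0.68 log units; beyond the scatter), so among these compounds only the benzylamino compound stands apart from butylamino, and chain length alone does not reproduce its value. Nothing shown here accounts for that difference.

The compounds shown leave open whether the phenyl group itself matters or whether another cyclic group, such as cyclohexylmethylamino, would serve as well. They also leave open how a phenethylamino group, with a longer link to the phenyl, would compare with benzylamino.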